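The compounds below may be only part of what the source reports. "The series", "measured", "known", "first", "only" and "open" are said of these compounds alone.

Compound 1 `Nc1cc(N)c2nc(-c3ccccc3)c(Oc3ccc(Cl)c(Cl)c3)nc2c1` was tested in a functional assay on NCI-H226 cells (Homo sapiens) for inhibition, read by sulforhodamine B assay, with a stated time of 48 h (a higher number here means a weaker inhibitor of growth, a lower number a stronger inhibitor of growth), and in that test compound 1 gives 49000 nM. In this assay compound 2 `COc1ccc(CNc2nc3cc(N)cc(N)c3nc2-c2ccccc2)cc1` gives 70800 nM. These two numbers lie within the usual scatter of each other, so compound 1 cannot be set apart from compound 2 on the readings at hand; both are weak inhibitors of growth. Compound 3 `COc1ccc(Sc2nc3cc(N)cc(N)c3nc2-c2ccccc2)cc1` has not yet been measured. It differs from compound 1 by (4-methoxyphenyl)sulfanyl in place of 3,4-dichlorophenoxy on an aromatic carbon. Going by the values given here, no step between two measured compounds covers this change, so the size of its effect is unknown. Because compound 1 gives 49000 nM and compound 2 gives 70800 nM while carrying a quite different group on the shared core, compound 3 is expected to stay in the same weak range, and the step of a 1.1-fold higher number from compound 1 to compound 3 (0.05 log units; within the scatter) is expected to lie within the scatter. Compound 3 is estimated at 55000 nM, with a range from 18000 nM to 160000 nM.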

Compound 3, concentration for total growth inhibition: < 100000 nM
Compound 3: only a limit was reported; the forecaster's own chance of this, stated with the estimate: 20%; the middle value is on the limit's open side.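

Going by these compounds alone, for compound 3, only a limit was reported, so no step from compound 1 to compound 3 can be read: the limit of < 100000 nM in this assay, at which 1 of the 3 values shown sits. The compounds shown leave open how (4-methoxyphenyl)sulfanyl compares with 3,4-dichlorophenoxy on the shared core in this assay.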